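This account rests on a few compounds, and the source may have more. Where it says the series, first, only, none or still open, it means among the compounds named here.

In an assay on cells with melanin-concentrating hormone receptor 1 (Homo sapiens) as the target, read by radioligand binding (a lower number here means a stronger inhibitor, a higher number a weaker inhibitor), compound 1 `Nc1ccc2cccc(OC3CCCCC3)c2n1` gives 361 nM. Compound 2 `COCC(C)Oc1cccc2ccc(N)nc12` gives 606 nM in this assay, and the step of a 1.7-fold higher number from compound 1 to compound 2 (0.22 log units; within the scatter) stays within the scatter. Compound 3 `CCOCCOc1cccc2ccc(N)nc12` gives > 2000 nM in this assay, which is a limit of the measurement rather than a number. Compound 3 sits at the limit of > 2000 nM in this assay, at which 1 of the 3 values shown sits, and the steps of an at least 5.5-fold higher number from compound 1 to compound 3 (0.74 log units; beyond the scatter) and an at least 3.3-fold higher number from compound 2 to compound 3 (0.51 log units; beyond the scatter) place it as the weakest of the three measured compounds. Compound 4 `CCCCOc1cccc2ccc(N)nc12` differs from compound 3 by ethyl in place of ethoxy on a saturated chain carbon, two bonds along the chain from an oxygen on an aromatic ring. Both steps into compound 3 bear on this change, as each exchanged a plain carbon group for a chain carrying an ether oxygen and lost potency. Compound 4 is therefore expected to recover, with an estimated step of an at least 2.5-fold lower number from compound 3 to compound 4 (0.39 log units; beyond the scatter) in this assay. Compound 4 is estimated at 800 nM, within 300 nM to 2500 nM.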

Compound 4, half-maximal inhibitory concentration: 789 nM
Compound 4: the middle estimate sits 1.0-fold (0.01 log units) above what was measured, within the range that was stated.
By their numbers in this assay, from the lowest: compounds 1, 2 and 4 (each within the scatter of the next, the first and the last beyond it). At a limit, above all of these: compound 3.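

In this assay ethyl in place of ethoxy on a saturated chain carbon, two bonds along the chain from an oxygen on an aromatic ring, gives an at least 2.5-fold lower number from compound 3 to compound 4 (0.40 log units; beyond the scatter) and so ties the loss at compound 3 to this one exchange. Butyl in place of cyclohexyl gives a 2.2-fold higher number from compound 1 to compound 4 (0.34 log units; beyond the scatter) while butyl in place of 1-(methoxymethyl)ethyl gives a 1.3-fold higher number from compound 2 to compound 4 (0.11 log units; within the scatter) and so compound 2 goes against any reading that an ether oxygen in the chain costs potency by itself. The step into compound 4 is only a bound, because compound 3 stands at a limit: the limit of > 2000 nM in this assay, at which 1 of the 4 values shown sits. The compounds shown leave open how far compound 3 truly lies from compound 4, and whether a longer chain, or an amine or a carboxylic acid at the end of the chain, would keep this level.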